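Shifting the fluorine: from 4-fluorophenyl to 3-fluorophenyl

This account rests on a few compounds, and the source may have more. Where it says the series, first, only, none or still open, it means among the compounds named here.

In a physicochemical assay for lipophilicity, read by LC-MS, using the shake flask method, in phosphate buffer, measured as octanol-water partition, with a stated time of 2 h, at pH 7.4 (a lower number here means a more polar compound, a higher number a more lipophilic compound), compound 3 `OC[C@H]1O[C@H](OCc2cn(-c3ccc(F)cc3)nn2)[C@@H](O)[C@@H](O)[C@@H]1O` gives -0.15 and so holds the lower of the two numbers available. Compound 2 `Nc1ccc(-n2cc(CO[C@H]3O[C@H](CO)[C@@H](O)[C@H](O)[C@@H]3O)nn2)cc1` gives 0.2 and compound 1 `O=C(O)c1cccc(-n2cc(CO[C@H]3O[C@H](CO)[C@@H](O)[C@H](O)[C@@H]3O)nn2)c1` has "not determined" (no result reported) as its entry. Compound 4 `OC[C@H]1O[C@H](OCc2cn(-c3cccc(F)c3)nn2)[C@@H](O)[C@@H](O)[C@@H]1O` has yet to be measured. It keeps the atoms of compound 3 but joins them differently, with 3-fluorophenyl in place of 4-fluorophenyl on an aromatic nitrogen as the counted change and 3-fluorophenyl in place of 4-fluorophenyl on an aromatic nitrogen. Among the measured compounds shown here, only one measured step bears on this, and only loosely: a number 0.35 log units lower from compound 2 to compound 3 (beyond the scatter) is modest, with fluoro in place of amino on an aromatic carbon. That step exchanges one group for another, whereas here the entering and leaving groups have the same counts. For the measured compounds named here, no measured step shows a fluoro changing place, so a smaller shift is expected. The step expected in this assay is a number 0.05 log units higher from compound 3 to compound 4 (within the scatter) and this estimate lies within the scatter, with no firm direction. Compound 4 is estimated at -0.1 with -0.4 to 0.2 as the expected range.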

Compound 4, distribution coefficient: 0.18
Compound 4: the middle estimate sits 0.28 log units below what was measured, and the stated range covers the measured number.
By their numbers in this assay, from the lowest: compound 3; then compounds 4 and 2 (each within the scatter of the next).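

In this assay, moving the fluorine with no change in atoms is enough to give a step of its own: a number 0.33 log units higher from compound 3 to compound 4 (beyond the scatter). The earlier compounds shown here showed only an exchange of one group for another, a number 0.35 log units lower from compound 2 to compound 3 (beyond the scatter), and gave no sign of what a change of place alone would do on this aromatic ring. Among the compounds shown here, with 3-fluorophenyl in place of 4-aminophenyl on the aromatic nitrogen, the result is a number 0.02 log units lower from compound 2 to compound 4 (within the scatter), so here the two groups cannot be told apart, and nothing measured so far explains the shift.

On these data alone, whether a chlorine or a methoxy group changing place in the same way would give a step of similar size remains open. As far as these compounds go, it is also open whether a second fluorine on this ring would add to the step or leave the number unchanged.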